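The compounds below may be only part of what the source reports. "The series", "measured", "known", "first", "only" and "open" are said of these compounds alone.

Measured compounds:
- Compound 1 `Nc1ccccc1NC(=O)c1ccc(COc2ccc(Br)cc2)cc1`: in a functional assay on HepG2 cells (Homo sapiens) for antiproliferative activity, read by CCK-8 assay, with a stated time of 72 h (a higher number here means a weaker inhibitor, a lower number a stronger inhibitor), compound 1 gives > 32000 nM, a limit of the assay rather than a number.
- Compound 2 `O=C(/C=C/c1ccc(CN2CCc3ccccc32)cc1)NO`: compound 2 gives 14900 nM.
- Compound 3 `Nc1cc(F)ccc1NC(=O)c1ccc(COc2ccccc2)cc1`: compound 3 gives 7020 nM.

Of the two actual numbers in this assay, compound 2 holds the higher one; compound 3 sits lower, and that gap lies beyond the usual scatter. The value for compound 1 is a limit only, and the limit of > 32000 nM in this assay, at which 1 of the 3 values shown sits, marks where it sits. Going by the values given here, no pair of measured compounds differs in a single place, so no measured step is available to lean on.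

Compound 4 `Nc1ccccc1NC(=O)/C=C/c1ccc(CN2CCc3ccccc32)cc1` has not yet been measured. It differs from compound 2 as follows: 2-aminophenyl in place of hydroxy on an amide-type nitrogen. Compounds 1 and 3 carry the same 2-aminophenyl on an amide-type nitrogen, but with a different remainder, so they do not speak directly to the size of this change. In this assay the step is expected to be small, in either direction, and likely not beyond the scatter. The estimate for compound 4 is 12000 nM, within 3500 nM to 40000 nM, which amounts to an expected step of a 1.2-fold lower number from compound 2 to compound 4 (0.09 log units; within the scatter).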

Compound 4, half-maximal inhibitory concentration: > 32000 nM
Compound 4 ended at the assay's limit; the forecaster's own chance of this, stated with the estimate: 20%; at least 2.6-fold (0.42 log units) between middle value and limit.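

Compound 4 gives > 32000 nM in this assay, which is a limit of the assay and not a number. Going by these compounds alone, on the amide-type nitrogen, 2-aminophenyl in place of hydroxy supplies the first single-place step, an at least 2.1-fold higher number from compound 2 to compound 4 (0.33 log units; beyond the scatter), so this change on the shared core costs antiproliferative activity, and only a minimum can be stated for the size of the step. This limit is also not unusual within this small set: the limit of > 32000 nM in this assay, at which 2 of the 4 values shown sit.

From the compounds shown here alone, it remains open whether the loss follows the amino group of the 2-aminophenyl or the aromatic ring itself, and a plain phenyl on the same nitrogen would separate the two. Going by these compounds, it also remains open whether a fluorine on the 2-aminophenyl ring would bring compound 4 off the limit.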